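Fluoro for Methoxy on the Sulfonyl Aryl Group

The source may hold more compounds than are shown below. What is called first, only, known or untested is meant among the compounds shown, and "the series" means these compounds.

Of the compounds shown here, three sharing one core have been measured in an ADME assay on microsomes from liver (Homo sapiens) for metabolic stability, tested at 2.5 uM; a higher number here means faster removal of the compound, a lower number slower removal. Compound 1 `COc1ccc(-c2c(S(=O)(=O)c3cc(Cl)cc(Cl)c3)cnc3cc(F)ccc23)cc1` gives 1 mL/min. Compound 2 `COc1ccc(-c2c(S(=O)(=O)c3cccc(C#N)c3)cnc3cc(F)ccc23)cc1` gives 0.92 mL/min, and compound 3 `COc1ccc(-c2c(S(=O)(=O)c3ccc(OC)cc3)cnc3cc(F)ccc23)cc1` gives 1.18 mL/min. Compound 3 holds the highest of the three numbers, but its gaps to the others are within the scatter, so the three cannot be told apart.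

Compound 4 `COc1ccc(S(=O)(=O)c2cnc3cc(F)ccc3c2-c2ccc(F)cc2)cc1` has not yet been measured. It differs from compound 3 in this way: fluoro in place of methoxy on an aromatic carbon. Among the compounds with values here, no measured step exchanges a methoxy for a fluoro, so the closest guidance comes from the three swaps of the whole aryl group on the sulfonyl sulfur: a 1.1-fold lower number from compound 1 to compound 2 (0.04 log units; within the scatter), a 1.2-fold higher number from compound 1 to compound 3 (0.07 log units; within the scatter) and a 1.3-fold higher number from compound 2 to compound 3 (0.11 log units; within the scatter). Each of these larger exchanges left the number within the scatter, so a smaller exchange at the same group is expected to do the same, with a 1.1-fold lower number from compound 3 to compound 4 (0.05 log units; within the scatter) as the expected step. Compound 4 is therefore estimated at 1.05 mL/min, within a range of 0.6 mL/min to 1.9 mL/min.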

Compound 4, intrinsic clearance in a liver preparation (reported as CLH), per the amount of preparation that the assay uses: 1.71 mL/min
Estimate against measurement, compound 4: 1.6-fold (0.21 log units) below; measured number inside the range.
By their numbers in this assay, from the lowest: compounds 2, 1, 3 and 4 (each within the scatter of the next).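

Compound 4 keeps the 4-methoxyphenyl on the sulfonyl sulfur, so this exchange, 4-methoxyphenyl to 4-fluorophenyl, falls on the other aryl ring, which compounds 1, 2 and 3 all carry unchanged. Within the data shown here, compound 4 is thus the only compound here that alters that ring, and in this assay the step (a 1.4-fold higher number from compound 3 to compound 4 (0.16 log units; within the scatter)) stays within the usual scatter, so this single exchange does not separate the two compounds. Nothing measured here bears on what lies behind this result.

Going by these compounds, it remains open whether a different group at this place, such as an amine, a carboxylic acid or a longer chain, would give a step beyond the scatter. On these data alone, it is also open whether the 4-fluorophenyl would read the same with 3-cyanophenyl or 3,5-dichlorophenyl on the sulfonyl sulfur.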